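The compounds below may be only part of what the source reports. "The series", "measured", "known", "first", "only" and "open" are said of these compounds alone.

Measured in a functional assay on ACHN cells (Homo sapiens) for inhibition, read by sulforhodamine B assay, with a stated time of 48 h, tested at 10 uM; a lower number here means less inhibition, a higher number more inhibition at the concentration tested (going by the name of the read-out):
compound 1 `O=Cc1ccc(-c2cn3ccnc3c(-c3ccc4ncn(C5CCCCC5)c4c3)n2)cc1` — 11.6%
compound 2 `CCc1ccc(-c2cn3ccnc3c(-c3ccc4ncn(Cc5ccccc5)c4c3)n2)cc1` — 44.7%
compound 3 `Cc1cccc(-c2cn3ccnc3c(-c3ccc4ncn(Cc5ccccc5)c4c3)n2)c1` — 12.4%

Compound 3 stands second highest of the three numbers; compound 1 sits within the scatter of it, while the step of a number 32.3 percentage points lower from compound 2 to compound 3 (beyond the scatter) lies well beyond the scatter. Compound 4 `O=Cc1ccc(-c2cn3ccnc3c(-c3ccc4ncn(Cc5ccccc5)c4c3)n2)cc1` differs from compound 3 thus: 4-formylphenyl in place of 3-methylphenyl on an aromatic carbon. Going by the values given here, no measured step covers this exchange directly; the single measured step, a number 32.3 percentage points lower from compound 2 to compound 3 (beyond the scatter), concerns another pair of groups on the same aromatic carbon. Compound 1 does carry the 4-formylphenyl that enters here, though with a different group elsewhere, and its value lies within the scatter of compound 3. The step of a number 0.6 percentage points higher from compound 3 to compound 4 (within the scatter) is therefore expected to be none beyond the scatter. Compound 4 is estimated at 13%, with a range of 0% to 30%.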

Compound 4, a percentage reported as inhibition, at one concentration (the size of the read-out at that concentration, not a potency): 11.6%
Compound 4: middle estimate off by 1.4 percentage points, on the high side; the range from low to high includes it.
By their numbers in this assay, from the lowest: compounds 1, 4 and 3 (each within the scatter of the next); then compound 2.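

In this assay the step of a number 33.1 percentage points lower from compound 2 to compound 4 (beyond the scatter) shows that 4-formylphenyl, like 3-methylphenyl, stays far under the 4-ethylphenyl of compound 2. The step of a number 0.8 percentage points lower from compound 3 to compound 4 (within the scatter) separates these two groups by no more than the scatter. The step of no change at the digits printed from compound 1 to compound 4 (within the scatter) shows that, with 4-formylphenyl in place, benzyl and cyclohexyl on the aromatic nitrogen cannot be told apart.

No evidence at hand explains these numbers. Open, as far as these compounds go, is whether a longer chain such as propyl, or an amine, in place of the ethyl keeps the value of compound 2.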